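Adding a Methyl on the Outer Phenyl of Compound 3

A few compounds are considered here, and "the series" means these few. Any claim that something is new, unique, unknown or untested is made for them only; others in the source may bear on it.

Measured compounds:
compound 1 `O=c1[nH]cc(S(=O)(=O)Nc2ccccc2-c2cn(-c3ccccc3)nn2)c(=O)[nH]1`: 11800 nM
compound 2 `O=c1[nH]cc(S(=O)(=O)Nc2ccccc2-c2cn(-c3cccc(Cl)c3)nn2)c(=O)[nH]1`: 2270 nM
compound 3 `O=c1[nH]cc(S(=O)(=O)Nc2ccc(-c3cn(-c4ccccc4)nn3)cc2)c(=O)[nH]1`: 18800 nM

In a functional assay on SGC-7901 cells (Homo sapiens) for antiproliferative activity, read by MTT assay, with a stated time of 24 h (on this read-out lower numbers stand for stronger inhibition and higher numbers for weaker inhibition), compound 3 gives 18800 nM. Against compound 1 with 11800 nM the gap is within the usual scatter, while compound 2 with 2270 nM lies beyond it. Compound 4 `Cc1ccccc1-n1cc(-c2ccc(NS(=O)(=O)c3c[nH]c(=O)[nH]c3=O)cc2)nn1` differs from compound 3 by methyl in place of hydrogen on an aromatic carbon. Among the measured compounds shown here, only one measured step touches this outer phenyl: a 5.2-fold lower number from compound 1 to compound 2 (0.72 log units; beyond the scatter), with chloro in place of hydrogen, not methyl, and on a different linkage pattern. That step suggests substitution on this phenyl can lower the number, but the group and placement differ, so for compound 4 a smaller shift is expected, a 1.7-fold lower number from compound 3 to compound 4 (0.23 log units; within the scatter). Compound 4 is therefore estimated at 11000 nM, within 4000 nM to 25000 nM.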

Compound 4, half-maximal inhibitory concentration: 13600 nM
Compound 4: middle estimate off by 1.2-fold (0.09 log units), on the low side; the range from low to high includes it.
By their numbers in this assay, from the lowest: compound 2; then compounds 1, 4 and 3 (each within the scatter of the next).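

In this assay, the change from phenyl to 2-methylphenyl, with methyl ortho to a large group, gives a 1.4-fold lower number from compound 3 to compound 4 (0.14 log units; within the scatter), so this single added carbon leaves the number within the scatter. The earlier compounds shown here showed a shift on this outer phenyl only with chloro and on the other linkage pattern, so methyl at this place now stands as a change with no shift beyond the scatter. No measurement at hand offers an explanation for this result.

The compounds shown leave open whether chloro, an amine or a carboxylic acid on this phenyl of compound 3 would move the number beyond the scatter. They also leave open whether methyl elsewhere on this ring would behave as it does here.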